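The source may hold more compounds than are shown below. What is called first, only, known or untested is meant among the compounds shown, and "the series" means these compounds.

Values measured in an ADME assay on the whole organism (strain FVB) for pharmacokinetics, with Mus musculus as the target, read by LC-MS, at a dose of 30 mg/kg by the oral route; a higher number here means more compound in the circulation at the dose given, a lower number less compound in the circulation:
- compound 1 `NCCOc1ccc([C@H]2CC[C@]3(CC2)OOC2(O3)C3CC4CC(C3)CC2C4)cc1` gives 1370 ng.h/mL
- compound 2 `c1cc([C@H]2CC[C@]3(CC2)OOC2(O3)C3CC4CC(C3)CC2C4)ccc1OCCC1CCNCC1` gives 16000 ng.h/mL
- compound 3 `c1cc([C@H]2CC[C@]3(CC2)OOC2(O3)C3CC4CC(C3)CC2C4)ccc1OCC1CCNCC1` gives 4040 ng.h/mL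

Of these three, compound 3 stands in the middle, at 4040 ng.h/mL. Compound 4 `CC1(C)CC(O)(COc2ccc([C@H]3CC[C@]4(CC3)OOC3(O4)C4CC5CC(C4)CC3C5)cc2)CC(C)(C)N1` has not yet been measured. It carries 4-hydroxy-2,2,6,6-tetramethylpiperidin-4-yl in place of piperidin-4-yl on a saturated chain carbon bound to an oxygen on an aromatic ring.

Three measured steps involve this same part of the chain: a 2.9-fold higher number from compound 1 to compound 3 (0.47 log units; beyond the scatter), a 12-fold higher number from compound 1 to compound 2 (1.07 log units; beyond the scatter) and a 4.0-fold lower number from compound 2 to compound 3 (0.60 log units; beyond the scatter). Across these three compounds, the larger group goes with the higher number, and none goes against this. None of these steps adds a hydroxy or a methyl group, however, so the direction remains uncertain. Resting on a 4.0-fold lower number from compound 2 to compound 3 (0.60 log units; beyond the scatter), where the number fell with the smaller group, a modest rise is expected in this assay, though a fall cannot be ruled out. The expected step is a 2.2-fold higher number from compound 3 to compound 4 (0.35 log units; beyond the scatter). For compound 4 the estimated value is 9000 ng.h/mL, with an expected range from 2500 ng.h/mL to 30000 ng.h/mL.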

Compound 4, area under the concentration-time curve: 17300 ng.h/mL
Estimate against measurement, compound 4: 1.9-fold (0.28 log units) below; the measured number falls inside the stated range.
By their numbers in this assay, from the lowest: compound 1; then compound 3; then compounds 2 and 4 (each within the scatter of the next).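

In this assay, replacing piperidin-4-yl with 4-hydroxy-2,2,6,6-tetramethylpiperidin-4-yl gives a 4.3-fold higher number from compound 3 to compound 4 (0.63 log units; beyond the scatter) and so shows that this much larger, more heavily substituted group on the saturated chain carbon is compatible with high exposure. The overall gain is also clear in a 13-fold higher number from compound 1 to compound 4 (1.10 log units; beyond the scatter) but the link between a larger group and a higher number stops short of a further rise, as the comparison with (piperidin-4-yl)methyl gives a 1.1-fold higher number from compound 2 to compound 4 (0.03 log units; within the scatter) and leaves these two groups indistinguishable here. Nothing available explains why exposure changes with these groups. The compounds shown leave open whether the hydroxy group, the four methyl groups or both together account for the rise from compound 3 to compound 4. Comparing 4-hydroxypiperidin-4-yl and 2,2,6,6-tetramethylpiperidin-4-yl at this position would separate those contributions.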